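The source may hold more compounds than are shown below. What is called first, only, known or untested is meant among the compounds shown, and "the series" means these compounds.

Two compounds share one core and differ in the group attached to it. Compound 1 `COc1cc(-c2cc(-c3cc(C(C)C)c(O)cc3C)[nH]c(=O)c2C#N)cc(OC)c1OC` gives 82% in a functional assay for inhibition, tested at 80 ug/mL; a lower number here means a weaker effect, a higher number a stronger effect of the compound at the concentration tested. Compound 2 `Cc1cc(O)c(C(C)C)cc1-c1cc(-c2cccs2)c(C#N)c(=O)[nH]1` gives 63% in this assay, the lower of the two numbers, and its gap to compound 1 lies beyond the usual scatter. Compound 3 `COc1ccc(-c2cc(-c3cc(C(C)C)c(O)cc3C)[nH]c(=O)c2C#N)cc1` has not yet been measured. It differs from compound 2 in one place: 4-methoxyphenyl in place of thiophen-2-yl on an aromatic carbon. Because compound 1 gives 82% with a six-membered aromatic ring of carbon only in that place, a modest rise is expected, a number 9 percentage points higher from compound 2 to compound 3 (within the scatter). Compound 3 is estimated at 72%, with a range from 58% to 85%.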

Compound 3, a percentage reported as inhibition, at one concentration (the size of the read-out at that concentration, not a potency): 47.5%
Estimate against measurement, compound 3: 24.5 percentage points above; measured number below the stated range.
By their numbers in this assay, from the lowest: compound 3; then compound 2; then compound 1.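

In this assay putting 4-methoxyphenyl in place of thiophen-2-yl, ortho to a cyano group, gives a number 15.5 percentage points lower from compound 2 to compound 3 (beyond the scatter) and so shows that a six-membered aromatic ring of carbon only does not by itself raise the number at this position. Compound 1 gives 82% with such a ring and compound 3 gives 47.5% with one too, so the groups on that ring matter here. For the compounds shown here, nothing measured so far explains this step. Still open, on these data alone, is how a plain phenyl, or a phenyl carrying an amine or a carboxylic acid, would compare. Furan-2-yl in this place is also an open question.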